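Fluorine in Place of Hydrogen on the Shared Core

A few compounds are considered here, and "the series" means these few. Any claim that something is new, unique, unknown or untested is made for them only; others in the source may bear on it.

Three compounds have been measured in a functional assay on MDA-MB-231 cells (Homo sapiens) for cytotoxicity; a higher number here means a weaker inhibitor, a lower number a stronger inhibitor:
Compound 1 `COc1ccc(Cn2cc(/C=N\NC(=O)c3c[nH]c4ccccc34)c3ccccc32)cc1` gives 15100 nM.
Compound 2 `COc1ccc(Cn2cc(/C=N\NC(=O)c3c[nH]c4ccccc34)c3cc(OC)ccc32)cc1` gives 9800 nM.
Compound 3 `Cn1cc(C(=O)N/N=C\c2cn(Cc3ccc(Cl)cc3)c3cc(F)ccc23)c2ccccc21` gives > 100000 nM, which is a limit of the assay and not a number.

Compound 1 stands highest of the two numbers, while compound 2 is its nearest neighbour after a 1.5-fold lower number from compound 1 to compound 2 (0.19 log units; within the scatter). The value for compound 3 sits at the limit of > 100000 nM in this assay, at which 1 of the 3 values shown sits.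

Compound 4 `COc1ccc(Cn2cc(/C=N\NC(=O)c3c[nH]c4ccccc34)c3ccc(F)cc32)cc1` differs from compound 1 in one place: fluoro in place of hydrogen on an aromatic carbon. Within the data shown here, the only measured step on the same part of the shared core is the one from compound 1 to compound 2, and it stayed within the scatter. Compound 3 also carries a fluoro group, but it differs from compound 1 in more than one place, so no single step can be read from its limit. The expected step in this assay is therefore a 1.0-fold lower number from compound 1 to compound 4 (0.00 log units; within the scatter), with no change beyond the scatter. Compound 4 is estimated at 15000 nM, between 5000 nM and 45000 nM.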

Compound 4, half-maximal inhibitory concentration: 71200 nM
For compound 4 the middle estimate is 4.7-fold (0.68 log units) below the measured one; measured number above the stated range.
By their numbers in this assay, from the lowest: compounds 2 and 1 (each within the scatter of the next); then compound 4. At a limit, above all of these: compound 3.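

In this assay, the shared core proves sensitive to a very small change: a single fluoro on this aromatic carbon gives a 4.7-fold higher number from compound 1 to compound 4 (0.67 log units; beyond the scatter). A higher number means a weaker inhibitor, so replacing one hydrogen with one heavy atom is enough here to weaken compound 1 by more than the usual scatter. The earlier methoxy change, on a different carbon of the core, did not show this, since it gave a 1.5-fold lower number from compound 1 to compound 2 (0.19 log units; within the scatter), and nothing shown here explains the rise seen with fluoro.

The compounds shown carry only this one group at this carbon, so a single step cannot show whether the loss belongs to fluoro alone or to any replacement of hydrogen there. An amine or a carboxylic acid at the same carbon would help to separate those two readings.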